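Plasma half-life: swapping a benzoyl for an acetyl

A few compounds are considered here, and "the series" means these few. Any claim that something is new, unique, unknown or untested is made for them only; others in the source may bear on it.

Measured compounds and their values in an ADME assay on a cell-free system (plasma, Homo sapiens) for metabolic stability; a higher number here means that the compound lasts longer, a lower number that the compound disappears faster:
compound 1, `CCOC(=O)c1ccc(/N=N/N(C)C(=O)OCOC(=O)c2ccccc2O)cc1`, 0.567 h
compound 2, `Cc1ncc([N+](=O)[O-])n1CCOC(=O)CCCC(=O)OCCn1c([N+](=O)[O-])cnc1C`, 0.61 h
compound 3, `CCOC(=O)c1ccc(/N=N/N(C)C(=O)OCOC(=O)c2ccccc2)cc1`, 0.783 h

The three numbers sit close together. Among the compounds with values here, the only step between two compounds that differ in one place is the one from compound 1 to compound 3, a 1.4-fold higher number from compound 1 to compound 3 (0.14 log units; within the scatter), which stays within the scatter; the value of compound 2 differs from that of compound 3 by no more than the scatter as well. Nothing here separates compound 3 from the others.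

Compound 4, `CCOC(=O)c1ccc(/N=N/N(C)C(=O)OCOC(C)=O)cc1`, is derived from compound 3 by the change (methyl in place of phenyl on a carbonyl carbon). Within the data shown here, no measured step touches this part of the molecule: the one known step concerns a hydroxy on an aromatic ring, not the group on the carbonyl carbon, so it does not bear on the change at hand. Among the measured compounds shown here, with no relevant step to draw on, the expected step from compound 3 to compound 4 in this assay is a 1.1-fold lower number from compound 3 to compound 4 (0.05 log units; within the scatter), that is, none beyond the scatter. Compound 4 is therefore estimated at 0.7 h, with a range from 0.3 h to 1.6 h.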

Compound 4, half-life: 0.2 h
Compound 4: middle estimate off by 3.5-fold (0.54 log units), on the high side, and the stated range ends above it.
By their numbers in this assay, from the lowest: compound 4; then compounds 1, 2 and 3 (each within the scatter of the next).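

In this assay, within the data shown here, the group on this carbonyl carbon turns out to matter in a way the earlier compounds could not show: methyl in place of phenyl gives a 3.9-fold lower number from compound 3 to compound 4 (0.59 log units; beyond the scatter), the first step in the set that lies beyond the scatter. The same holds against the hydroxylated benzoyl, where methyl in place of 2-hydroxyphenyl gives a 2.8-fold lower number from compound 1 to compound 4 (0.45 log units; beyond the scatter), so among these three compounds both aromatic groups on this carbon stand above the methyl, while the hydroxy on the ring, at a 1.4-fold higher number from compound 1 to compound 3 (0.14 log units; within the scatter), stays within the scatter. The data given hold nothing that accounts for this difference.

The compounds shown leave open whether the loss of the ring itself or simply the change in the size of the group sets the result, a question that a cyclohexyl or a longer chain such as butyl on the same carbonyl carbon would address. They also leave open how an amine or a carboxylic acid on the benzoyl ring would read in this assay, with hydroxy as the only ring substituent here.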